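Adding a Methyl Next to a Urea on Rice

This account rests on a few compounds, and the source may have more. Where it says the series, first, only, none or still open, it means among the compounds named here.

Measured so far:
Compound 1, `C[C@H](NC(=O)Nc1ccc(C(F)(F)F)cc1)c1ccccc1`, gives 94% in an ADME assay on the whole organism with Oryza sativa as the target, tested at 1 uM; on this read-out lower numbers stand for a stronger effect and higher numbers for a weaker effect at the one concentration tested.
Compound 2, `C[C@H](NC(=O)Nc1ccc(F)cc1)c1ccccc1`, gives 97% in this assay.

Compound 2 stands highest of the two numbers, but its step of a number 3 percentage points higher from compound 1 to compound 2 (within the scatter) is within the scatter, so the two are alike. Compound 3, `Cc1cc(F)ccc1NC(=O)N[C@@H](C)c1ccccc1`, differs from compound 2 by methyl in place of hydrogen on an aromatic carbon. No measured step tests a methyl, and the one step shown on the same ring was small, so no change beyond the scatter is expected: a number 2 percentage points lower from compound 2 to compound 3 (within the scatter). Compound 3 is estimated at 95%, between 85% and 100%.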

Compound 3, a percentage reported as activity, at one concentration (the size of the read-out at that concentration, not a potency): 98%
For compound 3 the middle estimate is 3 percentage points below the measured one; measured number inside the range.
By their numbers in this assay, from the lowest: compounds 1, 2 and 3 (each within the scatter of the next).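

In this assay, methyl in place of hydrogen on an aromatic carbon ortho to a large group gives a number 1 percentage points higher from compound 2 to compound 3 (within the scatter). Going by these compounds alone, the earlier step changed only the group at the fluoro position, so this is the first sign that this ring carbon accepts an added methyl without a change that can be told from the scatter. Nothing available bears on why the number holds.

Going by these compounds, it remains open whether an amine or a longer chain such as propyl on this carbon would give a step beyond the scatter. On these data alone, it is also open whether methyl would behave the same way with trifluoromethyl in place of the fluoro group.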